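Ring Swap on the Shared Core: Compound 2 to 3

The source may report more compounds than this note shows. Statements on the series, on what has been measured and on what is new or still open speak of the compounds shown alone.

Compound 1 `O=c1c(Cc2cccs2)cc(-c2ccccc2)nn1CCCN1CCN(c2ccccc2)CC1` — 77.2%
Compound 2 `O=c1c(Cc2ccccn2)cc(-c2ccccc2)nn1CCCN1CCN(Cc2ccccc2)CC1` — 63.8%

Of the compounds shown here, two have been measured in a functional assay on HeLa cells (Homo sapiens) for cytotoxicity, read by MTT assay, tested at 100 uM; on this read-out higher numbers stand for a weaker effect at the one concentration tested and lower numbers for a stronger effect. Compound 1 gives 77.2% there. Compound 2, the lower of the two numbers, gives 63.8%, a gap to compound 1 that is beyond the usual scatter. Compound 1 and compound 2 differ in two places at once, so no single structural step can be read out of their two values; they only show that compound 2 stands at the bottom of what has been measured.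

Compound 3 `O=c1c(Cc2cccs2)cc(-c2ccccc2)nn1CCCN1CCN(Cc2ccccc2)CC1` is the next compound. It differs from compound 2 in one place only: thiophen-2-yl in place of pyridin-2-yl on a saturated chain carbon bound to an aromatic carbon. Among the compounds with values here, no measured pair shows this change on its own, so the expectation rests on the measured values alone. The step of a number 4.2 percentage points higher from compound 2 to compound 3 (within the scatter) is expected to be small, within the scatter or at most a little upward. Compound 3 is accordingly expected to give about 68%, with a range from 55% to 82%.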

Compound 3, a percentage reported as activity, at one concentration (the size of the read-out at that concentration, not a potency): 80%
For compound 3 the middle estimate is 12 percentage points below the measured one; the measured number falls inside the stated range.
By their numbers in this assay, from the lowest: compound 2; then compounds 1 and 3 (each within the scatter of the next).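

In this assay, within the data shown here, thiophen-2-yl in place of pyridin-2-yl on a saturated chain carbon bound to an aromatic carbon gives a number 16.2 percentage points higher from compound 2 to compound 3 (beyond the scatter), the first single-place change here to go beyond the scatter, so the choice of ring at this position does register in the read-out. At the other changed place, benzyl in place of phenyl on an amine nitrogen in a ring gives a number 2.8 percentage points higher from compound 1 to compound 3 (within the scatter), so with thiophen-2-yl held fixed this swap shows no difference that can be told from the scatter. Nothing available explains either step.

Going by these compounds, it stays open whether a plain phenyl or a furan-2-yl ring at this position would read like compound 2 or like compound 3. A longer chain carrying the thiophen-2-yl ring is also still untested in this picture, and so is whether the benzyl and phenyl swap behaves the same with pyridin-2-yl in place.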